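The source may report more compounds than this note shows. Statements on the series, on what has been measured and on what is new or still open speak of the compounds shown alone.

Compound 1, `Cc1ccc(OCc2cn(Cc3ccc([N+](=O)[O-])cc3)nn2)cc1`: in an ADME assay on PANC-1 cells (Homo sapiens) for inhibition, read by MTT assay, with a stated time of 48 h (a lower number here means a stronger inhibitor of growth, a higher number a weaker inhibitor of growth), compound 1 gives > 100 ug/mL, a limit of the assay rather than a number.
Compound 2, `Cc1ccc(OCc2cn(Cc3ccc(Cl)cc3)nn2)cc1`: in this assay compound 2 gives > 100 ug/mL, again a limit.
Compound 3, `Cc1ccc(OCc2cn(Cc3cccc(Cl)c3)nn2)cc1`: in this assay compound 3 gives > 100 ug/mL, again a limit.

Compound 2 therefore stands at a limit only, and so do the two other values shown, all three sitting at the limit of > 100 ug/mL in this assay, at which 3 of the 3 values shown sit. Compound 4, `Clc1ccc(Cn2cc(COc3ccc(Cl)cc3)nn2)cc1`, differs from compound 2 by chloro in place of methyl on an aromatic carbon. The two measured steps, a step that the two limits leave unreadable from compound 1 to compound 2 and a step that the two limits leave unreadable from compound 2 to compound 3, both run between limits and so give no readable size; neither touches the ring carrying the methyl, so nothing measured speaks to this change directly. With every value at the limit, the step from compound 2 to compound 4 in this assay cannot be expected to show anything readable, and the most likely outcome is again a limit. Compound 4 is estimated at about 150 ug/mL, within an expected range from 60 ug/mL to 400 ug/mL. The expected step is a step that the limit leaves unreadable from compound 2 to compound 4.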

Compound 4, concentration for 50% growth inhibition: > 100 ug/mL
Compound 4 gave a limit, no number; the forecaster's own chance of this, stated with the estimate: 85%; the middle value lies beyond the limit too.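

In this assay compound 4 gives > 100 ug/mL, a limit and not a number. Compound 2 also stands at a limit, so no step can be read between compound 2 and compound 4. The compounds shown leave open how strongly any of them inhibits growth, and whether any of these changes matters.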